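A few compounds are considered here, and "the series" means these few. Any claim that something is new, unique, unknown or untested is made for them only; others in the source may bear on it.

The measured compounds:
Compound 1, `CC[C@H](C)[C@H](NC(=O)CN(c1nc(Cl)nc2[nH]cnc12)C1CC1)C(=O)O`: in a functional assay on the whole organism (Tail, strain ICR) with Mus musculus as the target, in the tail flick test, with a stated time of 60 min, at a dose of 25 umol/kg by the oral route (a lower number here means a weaker effect, a higher number a stronger effect of the compound at the dose given), compound 1 gives 36%.
Compound 2, `O=C(O)CNC(=O)CN(c1nc(Cl)nc2[nH]cnc12)C1CC1`: in this assay compound 2 gives 38.9%.

Within the data shown here, compound 1 stands lowest of the two numbers, but its only neighbour is compound 2, and the step of a number 2.9 percentage points higher from compound 1 to compound 2 (within the scatter) lies within the usual scatter, so the two cannot be told apart. The unmeasured compound 3, `CC[C@H](C)[C@H](NC(=O)CN(c1nc(Cl)nc2[nH]cnc12)C1CC1)C(=O)OCc1ccccc1`, differs from compound 1 in a single place: benzyl in place of hydrogen on an oxygen next to a carbonyl group. Among the measured compounds shown here, no measured step changes the group on the oxygen next to a carbonyl group; the one measured step, a number 2.9 percentage points higher from compound 1 to compound 2 (within the scatter), concerns the sec-butyl group on the saturated chain carbon and stayed within the scatter. The data therefore give no ground for expecting a move beyond the scatter in this assay. For compound 3 the estimated step is a number 4 percentage points higher from compound 1 to compound 3 (within the scatter). For compound 3 the expected value is 40%, within a range from 15% to 65%.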

Compound 3, a percentage reported as activity, at one dose (the size of the read-out at that dose, not a potency): 40.6%
For compound 3 the middle estimate is 0.6 percentage points below the measured one; the range from low to high includes it.
By their numbers in this assay, from the lowest: compounds 1, 2 and 3 (each within the scatter of the next).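

Benzyl in place of hydrogen on an oxygen next to a carbonyl group, which turns carboxy into benzyloxycarbonyl, gives in this assay a step of a number 4.6 percentage points higher from compound 1 to compound 3 (within the scatter). Among these compounds, this is the first look at this position, and it shows that a free carboxy group is not needed for the read-out at this dose: a group of this size, with its six-membered aromatic ring, leaves compound 3 indistinguishable from compound 1. Nothing measured here offers an explanation of this result.

The compounds shown leave open whether a methyl or an ethyl group on the same oxygen would also stay within the scatter. They also leave open what an amine or a longer chain would do in place of the benzyl group.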